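Pyrimidin-2-yl in place of tert-butoxycarbonyl on a ring amine

A few compounds are considered here, and "the series" means these few. Any claim that something is new, unique, unknown or untested is made for them only; others in the source may bear on it.

Of the compounds shown here, three sharing one core have been measured in a functional assay on PC-3 cells (Homo sapiens) for inhibition, read by MTT assay, with a stated time of 72 h; a lower number here means a stronger inhibitor, a higher number a weaker inhibitor. Compound 1 `CN1CCN(c2cc(C(F)(F)F)nc(SCc3ccc(C(F)(F)F)cc3)n2)CC1` gives 34700 nM, compound 2 `CCN1CCN(c2cc(C(F)(F)F)nc(SCc3ccc(C(F)(F)F)cc3)n2)CC1` gives 27200 nM, and compound 3 `CC(C)(C)OC(=O)N1CCN(c2cc(C(F)(F)F)nc(SCc3ccc(C(F)(F)F)cc3)n2)CC1` gives 40600 nM. Compound 3 thus stands within the scatter of both other compounds, and the three cannot be ranked on these numbers.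

The compound still to be measured, compound 4 `FC(F)(F)c1ccc(CSc2nc(N3CCN(c4ncccn4)CC3)cc(C(F)(F)F)n2)cc1`, carries pyrimidin-2-yl in place of tert-butoxycarbonyl on an amine nitrogen in a ring. Going by the values given here, three measured steps bear on this change, since each alters the group on that same nitrogen or the chain held there: a 1.3-fold lower number from compound 1 to compound 2 (0.11 log units; within the scatter), a 1.2-fold higher number from compound 1 to compound 3 (0.07 log units; within the scatter) and a 1.5-fold higher number from compound 2 to compound 3 (0.17 log units; within the scatter). All three lie within the scatter. Among the compounds with values here, none of them places an aromatic ring on that nitrogen, so the data offer no direct precedent for the entering group, and the forecast carries that uncertainty. On the evidence of these small steps, no change beyond the scatter is expected in this assay. The expected step is a 1.4-fold lower number from compound 3 to compound 4 (0.13 log units; within the scatter). For compound 4 the estimated value is 30000 nM, with an expected range from 14000 nM to 60000 nM.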

Compound 4, half-maximal inhibitory concentration: > 50000 nM
Compound 4: a limit, no number; the forecaster's own chance of this, stated with the estimate: 10%; at least 1.6-fold (0.22 log units) between middle value and limit.
By their numbers in this assay, from the lowest: compounds 2, 1 and 3 (each within the scatter of the next). At a limit, above all of these: compound 4.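

In this assay compound 4, the only compound shown with an aromatic ring on this amine nitrogen, gives > 50000 nM, which is a limit of the assay and not a number. The steps to it can be read only as floors, namely an at least 1.2-fold higher number from compound 3 to compound 4 (0.09 log units; that floor lies within the scatter), an at least 1.4-fold higher number from compound 1 to compound 4 (0.15 log units; that floor lies within the scatter) and an at least 1.8-fold higher number from compound 2 to compound 4 (0.26 log units; that floor lies within the scatter), and since each floor lies within the scatter, the change is not shown to differ from methyl, ethyl or tert-butoxycarbonyl by more than the scatter. What the result does add is one-sided: pyrimidin-2-yl on this nitrogen brings no lower number than the earlier groups, while the true size of the change stays hidden in this single capped reading: the limit of > 50000 nM in this assay, at which 1 of the 4 values shown sits.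

Going by these compounds, it remains open whether a phenyl ring, a pyridin-2-yl ring or a benzyl group on this nitrogen would read like pyrimidin-2-yl or like the three earlier groups. The shared core is also the same throughout, so the compounds shown do not tell what an amine or a carboxylic acid placed elsewhere on it would do to these numbers.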